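Replacing the 4-(fluoromethyl)cyclohexyl group in compound 2

A few compounds are considered here, and "the series" means these few. Any claim that something is new, unique, unknown or untested is made for them only; others in the source may bear on it.

Compound 1 `CC(C)(C)C#Cc1cc(N(C(=O)[C@H]2CC[C@H](C)CC2)[C@H]2CC[C@H](Oc3cccnc3)CC2)c(C(=O)O)s1` – 0.03
Compound 2 `CC(C)N(c1cc(C#CC(C)(C)C)sc1C(=O)O)C(=O)[C@H]1CC[C@H](CF)CC1` – 0.18
Compound 3 `CC(C)(C)C#Cc1cc(N(CCO)C(=O)[C@H]2CC[C@H](C)CC2)c(C(=O)O)s1` – "not determined" (no result reported)

Of the two numbers available in an ADME assay for protein binding, using equilibrium dialysis, at pH 7.4, tested at 2 uM (on this read-out higher numbers stand for a larger free fraction and lower numbers for a smaller free fraction), compound 2 stands highest with 0.18 and compound 1 lies lower with 0.03 as its result. That gap lies beyond the scatter. Compound 3 has no number. Compound 4 `CC(C)N(C(=O)[C@@H]1CC[C@@H]2C[C@@H]2CC1)c1cc(C#CC(C)(C)C)sc1C(=O)O` carries a group of 8 heavy atoms (8 carbon; one three-membered non-aromatic ring of carbon only, one seven-membered non-aromatic ring of carbon only) in place of a group of 8 heavy atoms (7 carbon, 1 fluorine; one six-membered non-aromatic ring of carbon only), on a carbonyl carbon and has not yet been measured. For the measured compounds named here, no measured pair tests this change, so the expectation is a loose one. The expected step of a 1.8-fold lower number from compound 2 to compound 4 (0.26 log units; within the scatter) is a small drop, no larger than the scatter. Compound 4 is estimated at 0.1 with an expected range from 0.05 to 0.18 as its likely span.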

Compound 4, unbound fraction: 0.05
Estimate against measurement, compound 4: 2.0-fold (0.30 log units) above; measured number inside the range.
By their numbers in this assay, from the lowest: compounds 1 and 4 (each within the scatter of the next); then compound 2.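

For the compounds shown here, compounds 2 and 4 give the first comparison in which only the group on the carbonyl carbon changes. In this assay, replacing the 4-(fluoromethyl)cyclohexyl group with the carbon-only group containing three-membered and seven-membered rings gives a 3.6-fold lower number from compound 2 to compound 4 (0.56 log units; beyond the scatter). The free fraction therefore responds to this position even when the heavy-atom count stays the same. No measurement available here explains the step. The compounds shown leave open how a 4-(hydroxymethyl)cyclohexyl or 4-(aminomethyl)cyclohexyl group would read at this position, and whether this step holds with another group on the amide-type nitrogen.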